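The source may hold more compounds than are shown below. What is called first, only, known or untested is meant among the compounds shown, and "the series" means these compounds.

Of the compounds shown here, two sharing one core have so far been measured in a functional assay on CCRF-CEM cells (Homo sapiens) for inhibition; on this read-out higher numbers stand for weaker inhibition and lower numbers for stronger inhibition. Compound 1, `OC[C@H]1OC(n2cnc3c(-c4cc5ccccc5o4)ncnc32)[C@H](O)[C@@H]1O`, gives 15000 nM in this assay, the highest of the two numbers. Compound 2, `OC[C@H]1OC(n2cnc3c(-c4ccccn4)ncnc32)[C@H](O)[C@@H]1O`, gives 900 nM in this assay. Within the data shown here, the single measured step, a 17-fold lower number from compound 1 to compound 2 (1.22 log units; beyond the scatter), shows that exchanging the group on that aromatic carbon can shift the number a long way. Compound 3, `OC[C@H]1OC(n2cnc3c(-c4ccc(O)cc4)ncnc32)[C@H](O)[C@@H]1O`, awaits measurement in this assay. It differs from compound 1 in one place: 4-hydroxyphenyl in place of 1-benzofuran-2-yl on an aromatic carbon. The measured step bears on this change, since it too removes 1-benzofuran-2-yl from the same aromatic carbon, although the group entering here is a different one, so the earlier step guides the direction more firmly than the size. The expected step is a 5.0-fold lower number from compound 1 to compound 3 (0.70 log units; beyond the scatter), a lower number, but smaller than the measured one. Compound 3 is therefore expected to give about 3000 nM in this assay, within a range from 700 nM to 12000 nM.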

Compound 3, half-maximal inhibitory concentration: 1250 nM
Compound 3: the middle estimate sits 2.4-fold (0.38 log units) above what was measured, within the range that was stated.
By their numbers in this assay, from the lowest: compounds 2 and 3 (each within the scatter of the next); then compound 1.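

Replacing 1-benzofuran-2-yl with 4-hydroxyphenyl on this aromatic carbon gives a 12-fold lower number from compound 1 to compound 3 (1.08 log units; beyond the scatter) in this assay, so a large drop now appears with two different incoming groups rather than one. Those two groups are hard to tell apart here, with a 1.4-fold higher number from compound 2 to compound 3 (0.14 log units; within the scatter), which means that, among the three compounds, only 1-benzofuran-2-yl stands apart. No measurement of any property of these groups is available to account for these steps.

As far as these compounds go, whether the hydroxyl of 4-hydroxyphenyl contributes remains open, and answering that would take a comparison with plain phenyl or 4-methoxyphenyl on the same core. Also open, from the compounds shown here alone, is how a group without an aromatic ring, such as an amine or a short alkyl chain, would behave on this carbon.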